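The source may report more compounds than this note shows. Statements on the series, on what has been measured and on what is new or still open speak of the compounds shown alone.

In a functional assay on HUVEC cells (Homo sapiens), read by BrdU incorporation, with a stated time of 72 h (on this read-out higher numbers stand for weaker inhibition and lower numbers for stronger inhibition), compound 1 (`Cc1ccc2nc(Cl)c(/C=C/C(=O)c3sccc3C)cc2c1`) gives 127 nM, compound 2 (`Cc1ccc2nc(Cl)c(/C=C/C(=O)c3ccc(Cl)s3)cc2c1`) gives 59.4 nM and compound 3 (`Cc1ccc2nc(Cl)c(/C=C/C(=O)c3cc(C)sc3C)cc2c1`) gives 229 nM. The closest gap for compound 3 is a 1.8-fold higher number from compound 1 to compound 3 (0.26 log units; within the scatter), so those two stand level. The widest is a 3.9-fold higher number from compound 2 to compound 3 (0.59 log units; beyond the scatter).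

Compound 4 (`Cc1ccc2nc(Cl)c(/C=C/C(=O)c3cc(Cl)sc3Cl)cc2c1`) differs from compound 3 by one swap: 2,5-dichlorothiophen-3-yl in place of 2,5-dimethylthiophen-3-yl on a carbonyl carbon. Both methyl groups on the thiophene give way to chlorines, with the 2,5-dichlorothiophen-3-yl group taking the place of the 2,5-dimethylthiophen-3-yl group on the carbonyl carbon. Going by the values given here, no measured step makes exactly this swap. The nearest evidence comes from the chlorinated compound 2, seen in a 2.1-fold lower number from compound 1 to compound 2 (0.33 log units; beyond the scatter) and again in a 3.9-fold higher number from compound 2 to compound 3 (0.59 log units; beyond the scatter), but both steps also move the point of attachment on the thiophene. They therefore suggest only a modest shift toward a lower number in this assay, and a result within the scatter would not be surprising. The expected change is a 2.3-fold lower number from compound 3 to compound 4 (0.36 log units; beyond the scatter). Compound 4 is thus estimated at 100 nM, with an expected range from 40 nM to 250 nM.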

Compound 4, half-maximal inhibitory concentration: 26.2 nM
Beside the measured number, compound 4's estimate is 3.8-fold (0.58 log units) above it; measured number outside the range, below it.
By their numbers in this assay, from the lowest: compound 4; then compound 2; then compounds 1 and 3 (each within the scatter of the next).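

Swapping both methyl groups for chlorines with the attachment to the carbonyl carbon unchanged gives the first direct reading of this change in this assay (an 8.7-fold lower number from compound 3 to compound 4 (0.94 log units; beyond the scatter)), and it is a larger step than any among the earlier compounds. The 2,5-dichlorothiophen-3-yl group also outdoes the two other thiophenes (a 2.3-fold lower number from compound 2 to compound 4 (0.36 log units; beyond the scatter); a 4.8-fold lower number from compound 1 to compound 4 (0.69 log units; beyond the scatter)), so compound 4 holds the lowest number of the four, with each of its steps beyond the scatter. Nothing available accounts for the size of this change.

The compounds shown leave open whether one chlorine alone would give part of this step or both are required. Also open, going by these compounds, is how a bromine, a methoxy group or an amine on the thiophene would read here.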